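Adding a Benzyl Group to the Core of Compound 1

The compounds below may be only part of what the source reports. "The series", "measured", "known", "first", "only" and "open" are said of these compounds alone.

Compound 1 `CCCCCCCCc1ccc(OCC(=O)Cn2cnnn2)cc1` and compound 2 `CCCCCCCCc1ccc(OCC(=O)Cn2nnc(-c3cccnc3)n2)cc1` share a common core and were both tested in an ADME assay on S9 fraction from liver (Rattus norvegicus) for metabolic stability, read by LC-MS, using NADPH, with a stated time of 30 min; a higher number here means that more of the compound is left, a lower number that less of the compound is left. In this assay compound 1 gives 22%, and compound 2 gives 12%. Of these two numbers, compound 1 holds the higher one, yet the gap to compound 2 lies within the scatter of repeated measurements, so the pair cannot be ranked with confidence. Compound 3 `CCCCCCCCc1ccc(OCC(=O)Cn2nnnc2Cc2ccccc2)cc1` has not yet been measured in this assay. Compared with compound 1, it carries benzyl in place of hydrogen on an aromatic carbon. Going by the values given here, no measured step between compounds that differ in only one place exists here, so there is no direct precedent for this change. Since compound 1 gives 22%, a modest downward step is expected, although an outcome within the scatter would not be surprising. Compound 3 is estimated to give 15%, with a likely range from 5% to 30%. The step this implies is expected to be a number 7 percentage points lower from compound 1 to compound 3 (within the scatter).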

Compound 3, percent of the compound remaining: 26%
For compound 3 the middle estimate is 11 percentage points below the measured one, within the range that was stated.
By their numbers in this assay, from the lowest: compounds 2, 1 and 3 (each within the scatter of the next, the first and the last beyond it).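

In this assay, going by these compounds alone, benzyl in place of hydrogen on an aromatic carbon gives a number 4 percentage points higher from compound 1 to compound 3 (within the scatter), which is the first step in one place at this position. The position, on an aromatic carbon of a five-membered aromatic ring with 4 nitrogen, therefore carries a benzyl group, with its six-membered aromatic ring of carbon only, without the percent remaining leaving the scatter around compound 1. No measurement on these compounds accounts for this step.

This single step does not show whether any group on this carbon can move the percent remaining beyond the scatter. From the compounds shown here alone, an amine, a carboxylic acid or a longer chain in place of benzyl remains open, as does whether such a group would give the same reading as compound 3.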